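A Chlorine Shift on a Scaffold at the Limit

This account rests on a few compounds, and the source may have more. Where it says the series, first, only, none or still open, it means among the compounds named here.

The compounds are compared in a functional assay on PC-3 cells (Homo sapiens) for cytotoxicity, read by MTT assay; a lower number here means a stronger inhibitor, a higher number a weaker inhibitor. Compound 1, `Cc1nc(Nc2cccc(Cl)c2)sc1C(=O)/C=C/c1ccc(Cl)cc1`, reaches only the limit of that assay, since compound 1 gives > 25000 nM. Compound 2, `Cc1ccccc1Nc1nc(C)c(C(=O)/C=C/c2ccccc2Cl)s1`, likewise returns a limit rather than a number, as compound 2 gives > 25000 nM in this assay. Both readings therefore rest at the limit of > 25000 nM in this assay, at which 2 of the 2 values shown sit, and the data do not say how far past that limit either compound lies.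

Compound 3, `Cc1ccccc1Nc1nc(C)c(C(=O)/C=C/c2ccc(Cl)cc2)s1`, has not yet been tested in this assay. It differs from compound 2 in a single place: 4-chlorophenyl in place of 2-chlorophenyl on a double-bonded chain carbon bound to a double-bonded chain carbon. Compound 1 already carries the 4-chlorophenyl on that chain carbon and gives a limit, compound 1 being reported at > 25000 nM. The step that the limit leaves unreadable from compound 2 to compound 3 is accordingly expected to be none beyond the scatter, with compound 3 expected to remain a limit. Compound 3 is estimated at 35000 nM, within a range from 10000 nM to 120000 nM.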

Compound 3, half-maximal inhibitory concentration: > 25000 nM
Compound 3: no number, only a limit; the forecaster's own chance of this, stated with the estimate: 80%; the middle value does not contradict the limit.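

In this assay compound 3 gives > 25000 nM, a limit and not a number. No step from compound 2 or from compound 1 to compound 3 can be read, since all three compounds rest at one limit: the limit of > 25000 nM in this assay, at which 3 of the 3 values shown sit.

The compounds shown leave open how far past that limit each lies, and whether either group exchange changes cytotoxicity at all.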